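Swapping Nitro for Fluoro on the Outer Phenoxy Ring

A few compounds are considered here, and "the series" means these few. Any claim that something is new, unique, unknown or untested is made for them only; others in the source may bear on it.

Compound 1 `COc1cc(OC)c2c(=O)cc(C(=O)Nc3ccc(N4CCN(C)CC4)cc3)[nH]c2c1`: in an ADME assay on BJ cells (Homo sapiens) for antiproliferative activity, with a stated time of 72 h (a lower number here means that less compound is needed, a higher number that more compound is needed for the effect), compound 1 gives > 19800 nM, which is a limit of the assay and not a number.
Compound 2 `COc1cc(OC)c2c(=O)cc(C(=O)Nc3ccc(Oc4ccc([N+](=O)[O-])cc4)cc3)[nH]c2c1`: in this assay compound 2 gives > 22900 nM, again a limit rather than a measured number.

Compound 2 therefore stands only at a limit: the assay reports that more compound would be needed than the highest amount tested, and nothing more. Among the compounds with values here, the single step between the measured compounds, a step that the two limits leave unreadable from compound 1 to compound 2, runs from one limit to another and cannot be read, as both the limit of > 19800 nM in this assay, at which 1 of the 2 values shown sits, and the limit of > 22900 nM in this assay, at which 1 of the 2 values shown sits, show.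

Compound 3 `COc1cc(OC)c2c(=O)cc(C(=O)Nc3ccc(Oc4ccc(F)cc4)cc3)[nH]c2c1` differs from compound 2 by fluoro in place of nitro on an aromatic carbon. Only the unreadable step bears on this change, so it gives no guidance on size or direction, and no step beyond the scatter can be expected from it. The plain expectation is that compound 3 also stays at a limit. For compound 3 the estimate in this assay is 25000 nM, with a range from 8000 nM to 80000 nM. The expected step is a step that the limit leaves unreadable from compound 2 to compound 3.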

Compound 3, half-maximal effective concentration: > 50000 nM
Compound 3: no number, only a limit; the forecaster's own chance of this, stated with the estimate: 75%; at least 2.0-fold (0.30 log units) between middle value and limit.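

In this assay compound 3 gives > 50000 nM, which is a limit and not a number. Within the data shown here, its steps from compound 1 and from compound 2 cannot be read, so these results yield no new step. The compounds shown leave open how much of each is needed for the effect, and whether fluoro in place of nitro changes that amount at all.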